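Swapping the ring on the ether oxygen in compound 2

The source may hold more compounds than are shown below. What is called first, only, known or untested is meant among the compounds shown, and "the series" means these compounds.

Compound 2 `COc1ccc(F)cc1CNCCCNc1ccnc2cc(Oc3ccc(F)cc3)ccc12` was tested in an ADME assay on HepG2 cells (Homo sapiens) for cytotoxicity, read by luminescence, CellTiter-Glo and ATP content, with a stated time of 72 h (a lower number here means that less compound is needed, a higher number that more compound is needed for the effect), and gave 6600 nM. Among the three compounds measured, compound 2 holds the second highest number. Its closest neighbour is compound 1 `COc1ccc(F)cc1CNCCCNc1ccnc2cc(Cc3ccc(C#N)cc3)ccc12`, which gives 6050 nM; the step of a 1.1-fold higher number from compound 1 to compound 2 (0.04 log units; within the scatter) is within the scatter. Farthest away is compound 3 `Fc1ccc(Oc2ccc3c(NCCCNCc4ccco4)ccnc3c2)cc1`, which gives 16000 nM; the step of a 2.4-fold higher number from compound 2 to compound 3 (0.38 log units; beyond the scatter) is beyond the scatter, though modest.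

Compound 4 `COc1ccc(F)cc1CNCCCNc1ccnc2cc(Oc3cccc(N(C)C)c3)ccc12` has not yet been measured. It differs from compound 2 by 3-(dimethylamino)phenyl in place of 4-fluorophenyl on an oxygen on an aromatic ring. Of the two measured steps, only the first bears directly on this change, since it also exchanged the group on that same oxygen-bearing position and produced a 1.1-fold higher number from compound 1 to compound 2 (0.04 log units; within the scatter), a shift that stayed within the scatter. The second step altered a different part of the molecule and is less informative here. On that basis, compound 4 is expected to sit close to compound 2, with a step of a 1.1-fold higher number from compound 2 to compound 4 (0.03 log units; within the scatter) that is unlikely to exceed the scatter. The estimate for compound 4 in this assay is therefore 7000 nM, with a likely range from 3500 nM to 14000 nM.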

Compound 4, half-maximal effective concentration: 3300 nM
Beside the measured number, compound 4's estimate is 2.1-fold (0.33 log units) above it; measured number outside the range, below it.
By their numbers in this assay, from the lowest: compounds 4, 1 and 2 (each within the scatter of the next); then compound 3.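

In this assay, the ether oxygen now carries a ring with a dimethylamino group, which adds a nitrogen and a hydrogen-bond acceptor that 4-fluorophenyl lacks, yet the step (a 2.0-fold lower number from compound 2 to compound 4 (0.30 log units; within the scatter)) still lies within the scatter. The comparison with the carbon-linked 4-cyanobenzyl group at the same place on the core (a 1.8-fold lower number from compound 1 to compound 4 (0.26 log units; within the scatter)) also lies within the scatter, so 4-cyanobenzyl, 4-fluorophenoxy and 3-(dimethylamino)phenoxy cannot be told apart here, despite their different linkers and ring substituents. None of the information available explains why these groups give such similar numbers, and this small set cannot establish a general tolerance at this position.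

On these data alone, what remains open is whether any group at this place can move the number beyond the scatter, for example a phenoxy ring carrying a carboxylic acid, or a much smaller methoxy group replacing the whole phenoxy unit. As far as these compounds go, it is also open whether furan-2-yl in place of 5-fluoro-2-methoxyphenyl on the chain would give a comparable step in a compound carrying 3-(dimethylamino)phenoxy.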